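From Benzylamino to a Thiophene Amine on the Saturated Ring

This account rests on a few compounds, and the source may have more. Where it says the series, first, only, none or still open, it means among the compounds named here.

Three compounds have been measured in an assay on CHO cells for agonist activity at 5-hydroxytryptamine receptor 1D (Homo sapiens), read by GTPgammaS binding; a lower number here means that less compound is needed, a higher number that more compound is needed for the effect:

compound 1 `c1ccc(CNC2CCN(CCCc3c[nH]c4ccc(-n5cnnc5)cc34)CC2)cc1` gives 7.6 nM
compound 2 `c1ccc(C2CCCCN2C2CCN(CCCc3c[nH]c4ccc(-n5cnnc5)cc34)CC2)cc1` gives 4.7 nM
compound 3 `CC(=O)Nc1ccc([C@H](C)NCC2CCN(CCCc3c[nH]c4ccc(-n5cnnc5)cc34)CC2)cc1` gives 3 nM

Among these three numbers compound 1 stands highest, meaning it needs the most compound of the three for a half-maximal effect. Its nearest neighbour is compound 2, whose number lies within the usual scatter of repeated measurements, so the two cannot be told apart. Compound 3 lies further off, beyond the scatter, so it needs less compound than compound 1.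

Compound 4 `CN(Cc1ccsc1)C1CCN(CCCc2c[nH]c3ccc(-n4cnnc4)cc23)CC1` has not yet been measured. It differs from compound 1 in one place:

methyl((thiophen-3-yl)methyl)amino in place of benzylamino on a saturated ring carbon

Within the data shown here, no pair of measured compounds differs in only one place, so there is no measured step to lean on. What the values of compound 1 and compound 2 show is that a different amine on the same saturated ring carbon gave a number within the scatter. On that basis the step from compound 1 to compound 4 is expected to be small, a 1.3-fold lower number from compound 1 to compound 4 (0.10 log units; within the scatter), with no clear direction beyond the scatter. Compound 4 is therefore estimated at 6 nM, in a range from 1.5 nM to 25 nM.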

Compound 4, half-maximal effective concentration: 4.2 nM
Estimate against measurement, compound 4: 1.4-fold (0.15 log units) above, and the stated range covers the measured number.
By their numbers in this assay, from the lowest: compounds 3, 4, 2 and 1 (each within the scatter of the next, the first and the last beyond it).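

In this assay, among these compounds, the single change on the saturated ring carbon gives a 1.8-fold lower number from compound 1 to compound 4 (0.26 log units; within the scatter) and is the first step here that isolates this position, so this swap cannot be told apart from no change at all. The change is not a minor one: a six-membered aromatic ring of carbon only gives way to a five-membered aromatic ring with a sulfur atom, and the hydrogen-bond donor of benzylamino is lost, yet the number stays within the scatter for this pair. Nothing measured on these compounds accounts for this result.

On these data alone, the ring swap and the added methyl on the amine nitrogen arrive together in this one step, so their separate contributions remain open, and a benzyl(methyl)amino group on the same ring carbon would begin to pull them apart. Also open, as far as these compounds go, is how far this position stretches beyond the aromatic amines seen so far, for instance to a cyclohexylmethylamino group, a carboxylic acid or a longer chain carrying the thiophene.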